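The source may report more compounds than this note shows. Statements on the series, on what has been measured and on what is new or still open speak of the compounds shown alone.

Compound 1, `CCCCCCCNc1cnc(C(=O)NCc2ccccc2)cn1`, in an ADME assay on MDCK cells (Canis lupus familiaris) for cytotoxicity, read by microscopy, with a stated time of 6 days (on this read-out lower numbers stand for higher toxicity in this test and higher numbers for lower toxicity in this test), gives a limit, > 100000 nM.
Compound 3, `CCCCNc1nccnc1C(=O)NCc1ccccc1`, in this assay gives a limit, > 100000 nM.
Compound 2, `O=C(NCc1ccccc1)c1cncc(Cl)n1`, in this assay gives "not determined" (no result reported).

Compound 2 therefore has no number of its own; the two other results sit at the limit of > 100000 nM in this assay, at which 2 of the 3 values shown sit, so no compound has yet shown a measured toxicity. Compound 4, `CCCCNc1cncc(C(=O)NCc2ccccc2)n1`, is the untested member. Going from compound 2 to compound 4 the change is butylamino in place of chloro on an aromatic carbon. For the measured compounds named here, since compound 1 and compound 3 each only reached a limit, no step in this assay beyond the scatter is expected from this change; the most likely outcome is another limit. Compound 4 is therefore expected to give about 100000 nM, with a range from 30000 nM to 300000 nM.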

Compound 4, minimum cytotoxic concentration: 100000 nM
Beside the measured number, compound 4's estimate shows no gap at the digits printed; the measured number falls inside the stated range.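

For the compounds shown here, compound 2 has no number of its own in this assay, and no step from it to compound 4 can be read. The compounds shown leave open whether any change on the shared core would bring a clearly lower value in this assay.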